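A few compounds are considered here, and "the series" means these few. Any claim that something is new, unique, unknown or untested is made for them only; others in the source may bear on it.

Three stereoisomers of one shared core have been run in an assay for inhibition of alpha-N-acetylgalactosaminidase (Gallus gallus), tested at 1000 uM; a higher number here means more inhibition at the concentration tested (going by the name of the read-out), a lower number less inhibition. Compound 1 `O=C(O)[C@@H]1NC[C@@H](O)[C@@H](O)[C@H]1O` gives 8.2%, compound 2 `O=C(O)[C@@H]1NC[C@@H](O)[C@H](O)[C@@H]1O` gives 10%, and compound 3 `O=C(O)[C@@H]1NC[C@H](O)[C@@H](O)[C@@H]1O` gives 3.4%. The number for compound 3 is the smallest of the three as recorded, but its gaps to the others are within the scatter: a number 4.8 percentage points lower from compound 1 to compound 3 (within the scatter) and a number 6.6 percentage points lower from compound 2 to compound 3 (within the scatter), with a number 1.8 percentage points higher from compound 1 to compound 2 (within the scatter) between the other pair. Compound 4 `O=C(O)[C@@H]1NC[C@@H](O)[C@H](O)[C@H]1O` is the remaining isomer; the change from compound 3 is the two compounds have the same atoms and bonds and differ only in configuration as drawn: 3 of 4 stereo elements differ; a stereocentre at a saturated ring carbon is drawn S in compound 3 and R in compound 4; a stereocentre at a saturated ring carbon is drawn R in compound 3 and S in compound 4; a stereocentre at a saturated ring carbon is drawn R in compound 3 and S in compound 4. All three measured steps, each a change of configuration alone (the fact that compounds 1 and 2 differ only in the configuration as drawn, (the fact that compounds 1 and 3 differ only in the configuration as drawn), (the fact that compounds 2 and 3 differ only in the configuration as drawn)), stayed within the scatter, so no step beyond the scatter is expected in this assay here either. Compound 4 is estimated at 7%, within 0% to 22%. The expected step is a number 3.6 percentage points higher from compound 3 to compound 4 (within the scatter).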

Compound 4, a percentage reported as inhibition, at one concentration (the size of the read-out at that concentration, not a potency): 1.3%
The estimate for compound 4 lay 5.7 percentage points above the measured number, and the stated range covers the measured number.
By their numbers in this assay, from the lowest: compounds 4, 3, 1 and 2 (each within the scatter of the next).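

In this assay, a change at one stereocentre alone gives a number 6.9 percentage points lower from compound 1 to compound 4 (within the scatter) and a number 8.7 percentage points lower from compound 2 to compound 4 (within the scatter); these are the first pairs shown that differ in only one of the four stereo elements. A change at three of the four gives a number 2.1 percentage points lower from compound 3 to compound 4 (within the scatter), so neither the smallest nor the largest configurational change shown leaves the scatter. All four stereoisomers of the shared core now lie within the scatter of one another, and no single stereocentre stands out. Still open, going by these compounds, is how the core behaves with a methyl ester or an amide in place of the carboxylic acid. Also open, on these data alone, is whether any stereocentre matters at another concentration.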